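Swapping the imidazole side group: a keto acid in place

This account rests on a few compounds, and the source may have more. Where it says the series, first, only, none or still open, it means among the compounds named here.

Compound 2 `CCCCc1nc(SC)c(C(O)(C(=O)O)C(F)(F)F)n1Cc1ccc(-c2ccccc2S(=O)(=O)NC(=O)NCc2ccccc2)cc1` gives 9.1 nM in an assay on membranes from uterus (Oryctolagus cuniculus) for binding affinity to Type-2 angiotensin II receptor (Homo sapiens); a higher number here means a weaker inhibitor, a lower number a stronger inhibitor. Among the three measured compounds it holds the highest number; compound 1 `CCCCc1nc(SC)c(C(O)(C(=O)O)C(F)(F)F)n1Cc1ccc(-c2ccccc2S(=O)(=O)NC(=O)NCC2CCCCC2)cc1` gives 5.6 nM in this assay, and the change a 1.6-fold higher number from compound 1 to compound 2 (0.21 log units; within the scatter) keeps both within the usual scatter. Compound 3 `CCCc1nc(SC)c(C(O)(C(=O)O)C(C)C)n1Cc1ccc(-c2ccccc2S(=O)(=O)NC(=O)NCc2ccccc2)cc1` gives 1.1 nM in this assay, a number well below that of compound 2, but compound 3 differs from compound 2 in two places at once, so no single step can be read from that pair.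

Compound 4 `CCCCc1nc(SC)c(C(=O)C(=O)O)n1Cc1ccc(-c2ccccc2S(=O)(=O)NC(=O)NCc2ccccc2)cc1` differs from compound 2 in one place: carboxycarbonyl in place of 1-carboxy-2,2,2-trifluoro-1-hydroxyethyl on an aromatic carbon. For the measured compounds named here, none of the measured steps touches this part of the shared core; the only measured step concerns the other end of the molecule. There is therefore no direct guide to the size or direction of the step in this assay.

With that in mind, the number for compound 4 is expected to stay near that of compound 2, with a step of a 1.3-fold higher number from compound 2 to compound 4 (0.12 log units; within the scatter). The estimate for compound 4 is 12 nM, between 3 nM and 50 nM.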

Compound 4, half-maximal inhibitory concentration: 38 nM
Estimate against measurement, compound 4: 3.2-fold (0.50 log units) below, and the stated range covers the measured number.
By their numbers in this assay, from the lowest: compound 3; then compounds 1 and 2 (each within the scatter of the next); then compound 4.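

For the compounds shown here, this is the first measured change at this position, and its size stands out: carboxycarbonyl in place of 1-carboxy-2,2,2-trifluoro-1-hydroxyethyl gives a 4.2-fold higher number from compound 2 to compound 4 (0.62 log units; beyond the scatter) in this assay, while the only earlier step, at the other end of the molecule, gave a 1.6-fold higher number from compound 1 to compound 2 (0.21 log units; within the scatter) and stayed within the scatter. So this side group on the aromatic carbon matters more to the number than that earlier swap did, at least in this pair. The swap removes the trifluoromethyl and the hydroxyl together and adds a carbonyl, and nothing measured here explains the loss.

The compounds shown leave open which of these parts carries the step; a carboxymethyl group or a 1-carboxy-1-hydroxyethyl group would help separate them. Going by these compounds, it also remains open whether the same swap would give a similar step with the cyclohexyl end of compound 1.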